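Compound 2 to compound 3: methoxy for chloro

The compounds below may be only part of what the source reports. "The series", "measured", "known", "first", "only" and "open" are said of these compounds alone.

Measured in a functional assay on HCT-116 cells (Homo sapiens) for antiproliferative activity, read by MTT assay, with a stated time of 72 h; on this read-out higher numbers stand for weaker inhibition and lower numbers for stronger inhibition:
Compound 1 `COc1ncc(-c2ccc3c(c2)N(C2CCCCC2)C(=O)CO3)cc1NS(=O)(=O)c1ccc(F)cc1` gives > 40000 nM as a limit
Compound 2 `O=C1COc2ccc(-c3cnc(Cl)c(NS(=O)(=O)c4ccc(F)cc4)c3)cc2N1c1ccc(Cl)cc1` gives 27900 nM as a number

Going by the values given here, compound 2 holds the only true number so far, at 27900 nM in this assay and so at the weak end of the scale. Compound 1 stands at > 40000 nM in the same read-out, which is a limit of the assay and not a number.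

The next compound to be read is compound 3 `COc1ncc(-c2ccc3c(c2)N(c2ccc(Cl)cc2)C(=O)CO3)cc1NS(=O)(=O)c1ccc(F)cc1`. It keeps the framework of compound 2 and changes one group, with methoxy in place of chloro on an aromatic carbon. The group sits next to the ring nitrogen and ortho to a ((4-fluorophenyl)sulfonyl)amino group.

Among the compounds with values here, no measured step isolates this exchange, so the expectation is loosely held. A modest move toward stronger inhibition in this assay is expected, and a result within the scatter of compound 2 would be no surprise. The expected size of the change is a 1.9-fold lower number from compound 2 to compound 3 (0.27 log units; within the scatter) in this estimate. For compound 3 the estimated value is 15000 nM with an expected range from 3000 nM to 40000 nM in the measurement to come.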

Compound 3, half-maximal inhibitory concentration: 19200 nM
Beside the measured number, compound 3's estimate is 1.3-fold (0.11 log units) below it; low and high end bracket the measured number.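

In this assay, the exchange of chloro for methoxy on an aromatic carbon next to the ring nitrogen, ortho to a ((4-fluorophenyl)sulfonyl)amino group, gives a 1.5-fold lower number from compound 2 to compound 3 (0.16 log units; within the scatter), so the two groups cannot be told apart at this position in this read-out. Going by these compounds alone, with methoxy held at this position, 4-chlorophenyl in place of cyclohexyl on the amide-type nitrogen in a ring gives an at least 2.0-fold lower number from compound 1 to compound 3 (0.31 log units; beyond the scatter), the only step so far that lies beyond the scatter, which places the readable difference at that nitrogen and not at the methoxy position. The full size of this step stays unread, as one of its ends is a limit of the assay and not a number: the limit of > 40000 nM in this assay, at which 1 of the 3 values shown sits.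

From the compounds shown here alone, it remains open whether an amine or a nitrile at the methoxy position would read differently from chloro and methoxy, and whether the same exchange would read alike with cyclohexyl on the ring nitrogen. The 4-fluorophenyl group on the sulfonyl is constant across the compounds shown, so the effect of replacing it, for instance with a carboxylic acid-bearing phenyl, is also open.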